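The source may hold more compounds than are shown below. What is called first, only, known or untested is meant among the compounds shown, and "the series" means these compounds.

Measured compounds in a functional assay on HL-60 cells (Homo sapiens) for antiproliferative activity, read by MTT assay; on this read-out lower numbers stand for stronger inhibition and higher numbers for weaker inhibition:
- compound 1, `CCC[C@@H]1O[C@H](COCc2ccccc2)[C@@H](OCc2ccccc2)[C@H](OCc2ccccc2)[C@H]1O`: 11700 nM
- compound 2, `CC(C)C[C@@H]1O[C@H](COCc2ccccc2)[C@@H](OCc2ccccc2)[C@H](OCc2ccccc2)[C@H]1O`: 8500 nM
- compound 3, `O[C@@H]1[C@@H](OCc2ccccc2)[C@H](OCc2ccccc2)[C@@H](COCc2ccccc2)O[C@H]1c1ccccc1`: 26300 nM

Compound 3 stands at the highest number of the three; the step from compound 1 is a 2.2-fold higher number from compound 1 to compound 3 (0.35 log units; beyond the scatter) and that from compound 2 is a 3.1-fold higher number from compound 2 to compound 3 (0.49 log units; beyond the scatter), both beyond the scatter, so compound 3 is the weakest inhibitor of the measured set in this assay. Compound 1 and compound 2 differ by a 1.4-fold lower number from compound 1 to compound 2 (0.14 log units; within the scatter), which is within the scatter.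

Compound 4, `CC[C@@H]1O[C@H](COCc2ccccc2)[C@@H](OCc2ccccc2)[C@H](OCc2ccccc2)[C@H]1O`, differs from compound 3 in one place: ethyl in place of phenyl on a saturated ring carbon. The two measured steps that bear on this change both run the other way, from an alkyl chain to phenyl on that ring carbon, and both give modestly higher numbers, a 2.2-fold higher number from compound 1 to compound 3 (0.35 log units; beyond the scatter) and a 3.1-fold higher number from compound 2 to compound 3 (0.49 log units; beyond the scatter). Reversing the sense, a modest fall in the number is expected for compound 4, of about the size seen between the alkyl-bearing compounds and compound 3, roughly the step of a 2.2-fold lower number from compound 3 to compound 4 (0.34 log units; beyond the scatter). The estimate for compound 4 in this assay is 12000 nM, with a range from 5000 nM to 30000 nM.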

Compound 4, half-maximal inhibitory concentration: 8200 nM
Compound 4: the middle estimate sits 1.5-fold (0.17 log units) above what was measured; the range from low to high includes it.
By their numbers in this assay, from the lowest: compounds 4, 2 and 1 (each within the scatter of the next); then compound 3.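

In this assay, ethyl in place of phenyl on the saturated ring carbon next to the ring oxygen gives a modest step beyond the scatter (a 3.2-fold lower number from compound 3 to compound 4 (0.51 log units; beyond the scatter)), so a third alkyl group now stands apart from phenyl at this position. Among the alkyl groups, ethyl, propyl and isobutyl cannot be told apart in this read-out, as both remaining steps lie within the scatter (a 1.0-fold lower number from compound 2 to compound 4 (0.02 log units; within the scatter); a 1.4-fold lower number from compound 1 to compound 4 (0.15 log units; within the scatter)). No supporting measurement accounts for the separation of phenyl from these alkyl groups.

On these data alone, whether a chain longer than isobutyl keeps the number at the level of these alkyl groups remains open. So does the effect of an amine or a carboxylic acid at the end of the chain on this ring carbon, or of a benzyl group in place of phenyl.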